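This account rests on a few compounds, and the source may have more. Where it says the series, first, only, none or still open, it means among the compounds named here.

In a functional assay on MCF7 cells (Homo sapiens) for antiproliferative activity (a lower number here means a stronger inhibitor, a higher number a weaker inhibitor), the series offers few readable numbers. Compound 1 `Nc1ccc(-c2nc3ccccc3s2)cc1I`, which also carries iodo, gives < 1 nM, a limit. Compound 2 `CC(=O)Nc1ccc(-c2nc3ccccc3s2)cc1C` gives > 10000 nM, also a limit. Compound 3 `CC(=O)Nc1ccc(-c2nc3ccccc3s2)cc1Br` gives > 10 nM, again a limit, so its standing is known from one side only. Compound 4 `CC(=O)Nc1ccc(-c2nc3ccccc3s2)cc1I` differs from it by a single exchange, iodo in place of bromo on an aromatic carbon, ortho to an acetamido group. For the measured compounds named here, the one measured step bearing on this is a step that the two limits leave unreadable from compound 2 to compound 3, so it gives no size to carry over. In this assay the expected step is modest, with no firm direction: a step that the limit leaves unreadable from compound 3 to compound 4. For compound 4 the estimated value is 50 nM, with an expected range of 3 nM to 3000 nM.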

Compound 4, half-maximal inhibitory concentration: > 100 nM
Compound 4 gave a limit, no number; the forecaster's own chance of this, stated with the estimate: 45%; middle value at least 2.0-fold (0.30 log units) away from the limit.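

In this assay, with iodo held in place, acetyl in place of hydrogen on the nitrogen gives an at least 100-fold higher number from compound 1 to compound 4 (2.00 log units; beyond the scatter). For the compounds shown here, this is the first readable step, and it falls on the nitrogen rather than on the halogen position. The steps among compound 2, compound 3 and compound 4 cannot be read, as all three values are limits.

As far as these compounds go, whether iodo and bromo differ at this position ortho to an acetamido group stays open. From the compounds shown here alone, the standing of chloro there, or of a longer acyl chain on the nitrogen, is also open.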